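The compounds below may be only part of what the source reports. "The series", "measured", "known", "first", "only" and "open" are said of these compounds alone.

Compound 1, `COc1ccc2c(=O)c(-c3cc(OC)c(OC)cc3OC)coc2c1`: 5200 nM
Compound 2, `COc1cc(OC)c(-c2coc3cc(OCc4ccc(Br)cc4)ccc3c2=O)cc1OC`: 1180 nM
Compound 3, `COc1cc(OC)c(-c2coc3cc(OCc4ccccc4C#N)ccc3c2=O)cc1OC`: 2140 nM

These three share one core and differ only at the oxygen on the aromatic ring, where compound 1 carries hydrogen and compounds 2 and 3 carry a substituted benzyl group. In a functional assay on B16 cells (Mus musculus) for antiproliferative activity, read by MTT assay, with a stated time of 24 h (a lower number here means a stronger inhibitor, a higher number a weaker inhibitor), compound 2 gives the lowest number of the three; it is beyond the scatter from compound 1, as the step of a 4.4-fold lower number from compound 1 to compound 2 (0.64 log units; beyond the scatter) shows, whereas compound 3 sits within the scatter of it, a 1.8-fold higher number from compound 2 to compound 3 (0.26 log units; within the scatter).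

Compound 4, `COc1cc(OC)c(-c2coc3cc(OCc4ccc(C(F)(F)F)cc4)ccc3c2=O)cc1OC`, has not yet been measured. It differs from compound 2 in one place: trifluoromethyl in place of bromo on an aromatic carbon. The measured step that bears most directly on this change is the exchange of one substituted benzyl for another, a 1.8-fold higher number from compound 2 to compound 3 (0.26 log units; within the scatter), which stayed within the scatter. The larger steps of a 4.4-fold lower number from compound 1 to compound 2 (0.64 log units; beyond the scatter) and a 2.4-fold lower number from compound 1 to compound 3 (0.39 log units; beyond the scatter) concern adding the whole benzyl group, which compound 4 keeps. A step within the scatter is therefore expected in this assay, with no clear direction. Compound 4 is expected to give 1300 nM, with a range from 600 nM to 2800 nM. This amounts to an expected step of a 1.1-fold higher number from compound 2 to compound 4 (0.04 log units; within the scatter).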

Compound 4, half-maximal inhibitory concentration: 5400 nM
Estimate against measurement, compound 4: 4.2-fold (0.62 log units) below; measured number outside the range, above it.
By their numbers in this assay, from the lowest: compounds 2 and 3 (each within the scatter of the next); then compounds 1 and 4 (each within the scatter of the next).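

The benzyl group alone does not set the number in this assay: what it carries on its aromatic carbon, para to a large group, also counts, as trifluoromethyl in place of bromo shows (a 4.6-fold higher number from compound 2 to compound 4 (0.66 log units; beyond the scatter)). That exchange leaves the benzyl group in place and still gives a step beyond the scatter, unlike the earlier exchange of 4-bromophenyl for 2-cyanophenyl, and compound 4 also separates from the other substituted benzyl compound (a 2.5-fold higher number from compound 3 to compound 4 (0.40 log units; beyond the scatter)). Adding a benzyl group to the oxygen therefore does not always pay off: compounds 2 and 3 lay beyond the scatter of compound 1, while 4-(trifluoromethyl)benzyl, the exception among the three, stays within it (a 1.0-fold higher number from compound 1 to compound 4 (0.02 log units; within the scatter)).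

No measurement offered here explains why bromo and trifluoromethyl part so clearly in this assay. Still open, on these data alone, is how a chloro, a methyl or an amine would behave on that same aromatic carbon, and whether a longer chain between the oxygen and the aromatic ring would keep the number seen for compound 2.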